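The source may hold more compounds than are shown below. What is called first, only, known or untested is meant among the compounds shown, and "the series" means these compounds.

Compound 2 `O=C(O)/C=C/C(=O)c1ccc(Br)cc1` gives 18700 nM in a functional assay on HeLa cells (Homo sapiens) for inhibition, read by MTT assay, with a stated time of 72 h (on this read-out higher numbers stand for weaker inhibition and lower numbers for stronger inhibition), the lowest of the three numbers recorded. Compound 1 `CCc1ccc(C(=O)/C=C/C(=O)O)cc1` gives 27800 nM in this assay, and compound 3 `COc1ccc(C(=O)/C=C/C(=O)O)c(OC)c1OC` gives 96200 nM in this assay. Within the data shown here, the step of a 1.5-fold lower number from compound 1 to compound 2 (0.17 log units; within the scatter) is the only single-point change measured so far, and it shows that swapping one group for another on the aromatic ring barely moved the number. Compound 3 stands well apart, but it differs from compound 2 in more than one place and offers no direct comparison.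

Compound 4 `O=C(O)/C=C/C(=O)c1ccccc1` is the unsubstituted parent: hydrogen in place of bromo on an aromatic carbon. Among the measured compounds shown here, no measured step removes a group in this way, so the expectation rests on the weak sensitivity seen in the step from compound 1 to compound 2. On that basis compound 4 is expected to show a step of a 1.4-fold higher number from compound 2 to compound 4 (0.14 log units; within the scatter) in this assay, that is, little change beyond the scatter, perhaps toward a slightly higher number. Compound 4 is therefore estimated at 26000 nM in this assay, within a range of 10000 nM to 65000 nM.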

Compound 4, half-maximal inhibitory concentration: 30600 nM
Estimate against measurement, compound 4: 1.2-fold (0.07 log units) below; low and high end bracket the measured number.
By their numbers in this assay, from the lowest: compounds 2, 1 and 4 (each within the scatter of the next); then compound 3.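

In this assay, the step with hydrogen in place of bromo is a 1.6-fold higher number from compound 2 to compound 4 (0.21 log units; within the scatter) and the step with hydrogen in place of ethyl is a 1.1-fold higher number from compound 1 to compound 4 (0.04 log units; within the scatter), so neither separates the parent from its substituted partner. Among these compounds, until now, only two groups had been compared on this aromatic carbon, para to a group of 7 heavy atoms; the bare hydrogen now shows that bromo, ethyl and hydrogen cannot be told apart there on this read-out. Nothing measured here offers an explanation for this flat result.

On these data alone, whether an amine or a nitrile on this carbon would give a step beyond the scatter remains open. Also unresolved is which of its several differences accounts for compound 3 at 96200 nM.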